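Swapping the amide aryl group: fluorines to methoxy groups

This account rests on a few compounds, and the source may have more. Where it says the series, first, only, none or still open, it means among the compounds named here.

Compound 1 `O=C(CN1CCN(c2nnc(Cc3ccncc3)c3ccccc23)CC1)Nc1ccc(F)c(F)c1` is measured in a functional assay on MDA-MB-231 cells (Homo sapiens) for cytotoxicity, read by MTT assay, with a stated time of 72 h (on this read-out lower numbers stand for stronger inhibition and higher numbers for weaker inhibition), where compound 1 gives 0.84 nM, the lowest number among the three measured compounds. Compound 2 `O=C(CN1CCN(c2nnc(Cc3ccccc3)c3ccccc23)CC1)Nc1ccc(F)c(F)c1` gives 2750 nM in this assay, and compound 3 `Cc1ccc(NC(=O)CN2CCN(c3nnc(Cc4ccccc4)c4ccccc34)CC2)c(C)c1` gives 181000 nM. The step of a 3300-fold higher number from compound 1 to compound 2 (3.52 log units; beyond the scatter) shows how steeply the number rises when the ring on the saturated chain carbon is exchanged, and the step of a 66-fold higher number from compound 2 to compound 3 (1.82 log units; beyond the scatter) shows a further rise from changing the ring on the amide-type nitrogen.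

Compound 4 `COc1ccc(NC(=O)CN2CCN(c3nnc(Cc4ccncc4)c4ccccc34)CC2)cc1OC` differs from compound 1 in one place: 3,4-dimethoxyphenyl in place of 3,4-difluorophenyl on an amide-type nitrogen. Only the second of the measured steps touches the same position, and it moved beyond the scatter toward a higher number; the entering groups differ, so its size is only a rough guide. A rise beyond the scatter is therefore expected, somewhat smaller than that step. For compound 4 the expected step is a 30-fold higher number from compound 1 to compound 4 (1.47 log units; beyond the scatter). Compound 4 is estimated at 25 nM, with a range from 2.5 nM to 250 nM.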

Compound 4, half-maximal inhibitory concentration: 100 nM
Compound 4: the middle estimate sits 4.0-fold (0.60 log units) below what was measured, within the range that was stated.
By their numbers in this assay, from the lowest: compound 1; then compound 4; then compound 2; then compound 3.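

Going by these compounds alone, until now, the only step at this position came from compounds carrying phenyl on the saturated chain carbon, and the new pair shows that the position also matters with pyridin-4-yl there: in this assay the exchange of 3,4-difluorophenyl for 3,4-dimethoxyphenyl gives a 120-fold higher number from compound 1 to compound 4 (2.08 log units; beyond the scatter) on the amide-type nitrogen. The low number of compound 1 therefore rests on its 3,4-difluorophenyl group as well as on its pyridin-4-yl ring. Nothing measured here explains why the number rises with this exchange.

The compounds shown leave open whether the rise comes from losing the fluorines or from gaining the methoxy groups. Plain phenyl, or a ring with a single methoxy group, on the same nitrogen would help to separate these two parts of the change.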